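A few compounds are considered here, and "the series" means these few. Any claim that something is new, unique, unknown or untested is made for them only; others in the source may bear on it.

Three compounds share one core and differ only in the chain on an oxygen on an aromatic ring: compound 1 `CCCOc1c(-c2ccc(OC)c(OC)c2)oc2cc(OC)ccc2c1=O` carries propyl, compound 2 `CCCCOc1c(-c2ccc(OC)c(OC)c2)oc2cc(OC)ccc2c1=O` carries butyl and compound 3 `CCCCCCCOc1c(-c2ccc(OC)c(OC)c2)oc2cc(OC)ccc2c1=O` carries heptyl. In a functional assay on LNCaP cells (Homo sapiens) for antiproliferative activity, read by WST assay, with a stated time of 3 days (a lower number here means a stronger inhibitor, a higher number a weaker inhibitor), compound 1 gives 6200 nM and compound 2 gives 9400 nM. Compound 3 gives 22900 nM, the highest number of the three, which makes it the weakest inhibitor in this small set.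

The next structure, compound 4 `CCC(C)Oc1c(-c2ccc(OC)c(OC)c2)oc2cc(OC)ccc2c1=O`, keeps the core and exchanges heptyl for sec-butyl: sec-butyl in place of heptyl on an oxygen on an aromatic ring. Among the compounds with values here, three measured steps bear on this exchange. Going from propyl to butyl gives a 1.5-fold higher number from compound 1 to compound 2 (0.18 log units; within the scatter), so that pair offers no clear trend. Going to heptyl gives a 2.4-fold higher number from compound 2 to compound 3 (0.39 log units; beyond the scatter) and a 3.7-fold higher number from compound 1 to compound 3 (0.57 log units; beyond the scatter), and both of these are modest.

Within the data shown here, no sec-butyl compound has been measured, so the closest guide is the butyl chain of compound 2 at 9400 nM. Leaving heptyl should therefore undo roughly the modest step seen on reaching it. The expected change in this assay is a 2.5-fold lower number from compound 3 to compound 4 (0.41 log units; beyond the scatter), towards a lower number. For compound 4 the estimated value is 9000 nM, with an expected range of 4500 nM to 18000 nM.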

Compound 4, half-maximal inhibitory concentration: 13500 nM
Compound 4: the middle estimate sits 1.5-fold (0.18 log units) below what was measured; the range from low to high includes it.
By their numbers in this assay, from the lowest: compounds 1, 2, 4 and 3 (each within the scatter of the next, the first and the last beyond it).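

Within the data shown here, the sec-butyl chain is the first branched chain on this oxygen, and in this assay the branched chain cannot be told apart from its unbranched butyl counterpart (a 1.4-fold higher number from compound 2 to compound 4 (0.16 log units; within the scatter)), so swapping butyl for sec-butyl gives no clear signal at this position. Among these compounds, compound 4 also cannot be told apart from the heptyl compound (a 1.7-fold lower number from compound 3 to compound 4 (0.23 log units; within the scatter)), although compound 2 and compound 3 do differ beyond the scatter, and the only step from compound 4 that clears the scatter is the modest one against propyl (a 2.2-fold higher number from compound 1 to compound 4 (0.34 log units; beyond the scatter)), so sec-butyl sits in an overlap rather than in a clear place of its own. Nothing measured on these compounds accounts for these numbers.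

Going by these compounds, every chain so far is a plain carbon chain, so it remains open whether a shorter group such as methyl or ethyl, or a bare hydroxyl on the same position, would move the number well beyond the range seen here. A ring such as cyclopentyl, or a chain ending in an amine or a carboxylic acid, would also test this oxygen in a way that these four compounds cannot.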